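The compounds below may be only part of what the source reports. "The series", "measured", "known", "first", "only" and "open" are said of these compounds alone.

Compound 1 `CCCOC(=O)/C=C/c1ccc(NC(=O)C2(NC(=O)c3ccc4c(C5CCCC5)c(-c5ncc(Cl)cn5)n(C)c4c3)CCC2)cc1OCC` and compound 2 `CCOc1cc(NC(=O)C2(NC(=O)c3ccc4c(C5CCCC5)c(-c5ncc(Cl)cn5)n(C)c4c3)CCC2)ccc1/C=C/C(=O)OCC(Cl)(Cl)Cl` have been measured; compound 3 `CCOc1cc(NC(=O)C2(NC(=O)c3ccc4c(C5CCCC5)c(-c5ncc(Cl)cn5)n(C)c4c3)CCC2)ccc1/C=C/C(=O)OCc1ccccc1` has not.

In an ADME assay (intestine, Rattus norvegicus) for pharmacokinetics, using microsomes (on this read-out lower numbers stand for a shorter-lived compound and higher numbers for a longer-lived compound), compound 1 gives > 5 h, a limit of the assay rather than a number. In this assay compound 2 gives > 5 h, likewise a limit. Between them lies a step that the two limits leave unreadable from compound 1 to compound 2, both values sitting at the limit of > 5 h in this assay, at which 2 of the 2 values shown sit. Compound 2 thus stands at the limit, with no number beyond it. Compound 3 differs from compound 2 in phenyl in place of trichloromethyl on a saturated chain carbon bound to an oxygen next to a carbonyl group. Going by the values given here, only the step from compound 1 to compound 2 bears on this change, and its size cannot be read, so no step beyond the scatter is assumed. Compound 3 is expected to give 5 h, between 2.5 h and 10 h, an estimated step of a number no higher from compound 2 to compound 3 (the limit leaves the size open).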

Compound 3, half-life: > 5 h
Compound 3: no number, only a limit (the forecaster's own chance of this, stated with the estimate: 65%); the middle value sits exactly at the limit.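

In this assay compound 3, like compound 1 and compound 2, stands at a limit and not at a number, so the steps among these three compounds cannot be read: the limit of > 5 h in this assay, at which 3 of the 3 values shown sit. The compounds shown leave open how long each half-life actually is and whether the changed groups make any difference to it.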